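The compounds below may be only part of what the source reports. "The series", "measured", "known", "first", "only" and "open" are said of these compounds alone.

In a functional assay on UACC-62 cells (Homo sapiens) (on this read-out higher numbers stand for weaker inhibition of growth and lower numbers for stronger inhibition of growth), compound 1 (`CC(C)(C)c1cc(/C=C/S(=O)(=O)Cc2ccc(Nc3ncnc4ccccc34)cc2)cc(C(C)(C)C)c1O`) gives 6000 nM and compound 2 (`COc1cc2ncnc(Nc3ccc(CS(=O)(=O)/C=C/c4ccc(Cl)cc4Cl)cc3)c2cc1OC`) gives 21000 nM as its growth-inhibition value. Compound 2 therefore holds the higher of the two numbers, which means the weaker inhibition of growth, and the gap between them lies beyond the usual scatter of repeated measurements. Compound 3 (`COc1cc2ncnc(Nc3ccc(CS(=O)(=O)/C=C/c4ccc(F)cc4)cc3)c2cc1OC`) carries 4-fluorophenyl in place of 2,4-dichlorophenyl on a double-bonded chain carbon bound to a double-bonded chain carbon and is otherwise the same as compound 2. Among the compounds with values here, no two measured compounds differ in one place only, so the data do not yet show how far such a swap moves the number in this assay or in which direction. Compound 2 at 21000 nM is the closest measured neighbour and so serves as the anchor for a prediction. The estimated change is a 1.3-fold lower number from compound 2 to compound 3 (0.12 log units; within the scatter) and is expected to stay within the scatter. In this assay compound 3 is expected at 16000 nM with an estimated range from 5000 nM to 50000 nM for repeated runs.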

Compound 3, concentration for 50% growth inhibition: > 100000 nM
Compound 3: a limit, no number (the forecaster's own chance of this, stated with the estimate: 15%); middle value at least 6.2-fold (0.79 log units) away from the limit.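

In this assay compound 3 gives > 100000 nM, which is a limit of the assay and not a number. Within the data shown here, this is the first change in a single place that can be read, and 4-fluorophenyl in place of 2,4-dichlorophenyl on a double-bonded chain carbon bound to a double-bonded chain carbon gives an at least 4.7-fold higher number from compound 2 to compound 3 (0.67 log units; beyond the scatter), so growth inhibition becomes weaker and the group at this position clearly matters. The step has a lower bound but no known full size, as the value on one side of it is only a limit: the limit of > 100000 nM in this assay, at which 1 of the 3 values shown sits.

The swap removes both chlorines and brings in a fluorine in one move, so the compounds shown do not separate the loss of chlorine from the gain of fluorine. They also leave open how a phenyl ring carrying an amine or a carboxylic acid would read in this assay, and whether the same swap would move the number in the same direction on the core of compound 1.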